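Chloro to bromo step from compound 2

The source may hold more compounds than are shown below. What is called first, only, known or untested is meant among the compounds shown, and "the series" means these compounds.

For the measured compounds named here, in a functional assay on HUVEC cells (Homo sapiens), read by BrdU incorporation, with a stated time of 72 h (on this read-out higher numbers stand for weaker inhibition and lower numbers for stronger inhibition), compound 2 (`Cc1ccc2nc(Cl)c(/C=C/C(=O)c3ccc(Cl)s3)cc2c1`) gives 59.4 nM and compound 3 (`Cc1ccc2cc(/C=C/C(=O)c3ccc(Cl)s3)c(Cl)nc2c1`) gives 49.5 nM as the only other number, so compound 2 stands within the scatter of compound 3. Compound 1 (`Cc1cc(C(=O)/C=C/c2cc3cccc(C)c3nc2Cl)c(C)s1`) carries the entry "not determined" (no result reported) and offers no number. Compound 4 (`Cc1ccc2nc(Cl)c(/C=C/C(=O)c3ccc(Br)s3)cc2c1`) awaits measurement. It differs from compound 2 by bromo in place of chloro on an aromatic carbon as bromo in place of chloro on an aromatic carbon, read further out as 5-chlorothiophen-2-yl to 5-bromothiophen-2-yl. Going by the values given here, no measured pair shows this change, so no step beyond the scatter is expected. The expected change is a 1.1-fold lower number from compound 2 to compound 4 (0.03 log units; within the scatter) and stays within the scatter. For compound 4 the estimated value is 55 nM with an expected range from 25 nM to 120 nM around it.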

Compound 4, half-maximal inhibitory concentration: 88.4 nM
Beside the measured number, compound 4's estimate is 1.6-fold (0.21 log units) below it; the measured number falls inside the stated range.
By their numbers in this assay, from the lowest: compounds 3, 2 and 4 (each within the scatter of the next).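

For the compounds shown here, this is the only pair that reads the change directly: on the carbon next to the ring sulfur, 5-chlorothiophen-2-yl to 5-bromothiophen-2-yl gives a 1.5-fold higher number from compound 2 to compound 4 (0.17 log units; within the scatter) in this assay, so the two halogens are not separated here. This single pair is all that speaks for the position. No measured property on hand bears on this result. As far as these compounds go, whether an amine, a methoxy group or a carboxylic acid on this carbon would move the number beyond the scatter stays open. So does the same halogen swap on the core of compound 3.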